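Widening the aryl ring on the double-bonded chain

A few compounds are considered here, and "the series" means these few. Any claim that something is new, unique, unknown or untested is made for them only; others in the source may bear on it.

Measured compounds:
compound 1 `O=C(/C=C/c1cccc(O)c1)c1cccc(-n2cc(-c3ccccc3)[nH]c2=O)c1` gives 2150 nM
compound 2 `O=C(/C=C/c1cccc(O)c1)c1cccc(-n2cc(-c3ccc(Cl)cc3)[nH]c2=O)c1` gives 1550 nM

Both values come from a functional assay on RPMI8266 cells (Homo sapiens) for inhibition; a higher number here means a weaker inhibitor of growth, a lower number a stronger inhibitor of growth. Compound 2 holds the lowest of the two numbers, and its nearest neighbour is compound 1, but the gap between them, a 1.4-fold lower number from compound 1 to compound 2 (0.14 log units; within the scatter), does not separate the two compounds with any confidence. For the measured compounds named here, that one step, chloro in place of hydrogen on an aromatic carbon, is the only measured comparison available.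

Compound 3 `COc1cc(/C=C/C(=O)c2cccc(-n3cc(-c4ccc(Cl)cc4)[nH]c3=O)c2)ccc1O` keeps the chloro-bearing ring of compound 2 and changes the other end of the molecule: 4-hydroxy-3-methoxyphenyl in place of 3-hydroxyphenyl on a double-bonded chain carbon bound to a double-bonded chain carbon. The measured step between compound 1 and compound 2 touches a different ring and does not bear on this change, so there is no comparison within these numbers that says how this assay responds to it. The expectation therefore rests on the starting point alone: a step of about a 1.0-fold lower number from compound 2 to compound 3 (0.01 log units; within the scatter) is expected, meaning no change beyond the scatter, with a wide range on either side. Compound 3 is estimated at 1500 nM, between 500 nM and 4500 nM.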

Compound 3, concentration for 50% growth inhibition: 1330 nM
Estimate against measurement, compound 3: 1.1-fold (0.05 log units) above; measured number inside the range.
By their numbers in this assay, from the lowest: compounds 3, 2 and 1 (each within the scatter of the next).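

Up to this point the only measured step concerned a different ring, so nothing showed how this assay responds to a change at this end of the molecule. Here the step is a 1.2-fold lower number from compound 2 to compound 3 (0.07 log units; within the scatter), which means that putting 4-hydroxy-3-methoxyphenyl in place of 3-hydroxyphenyl on a double-bonded chain carbon bound to a double-bonded chain carbon produces no change that can be told from the scatter, even though the entering group is the larger of the two. No measurement shown here offers an explanation for this result.

This single swap both adds a methoxy group and gives the hydroxy group a different place on the ring, so the compounds shown cannot separate what each of those two alterations does, and they leave open whether the two cancel out or neither matters. An amine or a carboxylic acid in place of the hydroxy group, or a longer chain such as ethoxy in place of the methoxy group, would show whether the number stays just as flat at this position or finally moves beyond the scatter.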